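Adding a second chloro to compound 2

A few compounds are considered here, and "the series" means these few. Any claim that something is new, unique, unknown or untested is made for them only; others in the source may bear on it.

Measured in a functional assay on HCT-116 cells (Homo sapiens) for antiproliferative activity, read by MTT assay, with a stated time of 72 h; a lower number here means a stronger inhibitor, a higher number a weaker inhibitor:
compound 1 `O=S1(=O)C=Cc2cccc(Nc3ccc(C(F)(F)F)cc3)c21`: 1440 nM
compound 2 `O=S1(=O)C=Cc2cccc(Nc3ccc(Cl)cc3)c21`: 260 nM
compound 3 `COc1ccc(Nc2cccc3c2S(=O)(=O)C=C3)cc1`: 1990 nM

Compound 2 gives the lowest number of the three, and its gaps to both others lie beyond the scatter. Compound 4 `O=S1(=O)C=Cc2cccc(Nc3ccc(Cl)c(Cl)c3)c21` keeps its chloro and gains another: chloro in place of hydrogen on an aromatic carbon. Within the data shown here, no measured step adds a group in this way, so the evidence is indirect. Two modest steps show that this assay responds to changing a single group: a 5.5-fold lower number from compound 1 to compound 2 (0.74 log units; beyond the scatter) and a 7.7-fold higher number from compound 2 to compound 3 (0.88 log units; beyond the scatter). A third, a 1.4-fold higher number from compound 1 to compound 3 (0.14 log units; within the scatter), stays within the scatter. Among the measured compounds shown here, a modest step to a lower number is therefore expected, although no measured step fixes its direction. The estimated change is a 1.7-fold lower number from compound 2 to compound 4 (0.24 log units; within the scatter). For compound 4 the estimated value is 150 nM, with an expected range of 60 nM to 400 nM.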

Compound 4, half-maximal inhibitory concentration: 680 nM
The estimate for compound 4 lay 4.5-fold (0.66 log units) below the measured number; measured number outside the range, above it.
By their numbers in this assay, from the lowest: compound 2; then compound 4; then compounds 1 and 3 (each within the scatter of the next).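

Adding chloro on an aromatic carbon, ortho to the chloro group of compound 2, gives a 2.6-fold higher number from compound 2 to compound 4 (0.42 log units; beyond the scatter) in this assay. The earlier steps shown here only exchanged one group for another, whereas this one shows that adding a group at this new position can also shift the number, and here it rises. No measurement shown here accounts for that rise. The compounds shown leave open whether the rise belongs to chloro or to any group at this position, as a fluoro, a methyl or an amine there would show.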